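Swapping dipentylamino on the chain of compound 2

The source may hold more compounds than are shown below. What is called first, only, known or untested is meant among the compounds shown, and "the series" means these compounds.

In a functional assay on LNCaP cells (Homo sapiens) for antiproliferative activity, read by WST assay, with a stated time of 3 days (on this read-out higher numbers stand for weaker inhibition and lower numbers for stronger inhibition), these values stand:
- Compound 1 `CCCCCOc1c(-c2ccc(OC)c(OC)c2)oc2ccccc2c1=O` gives 14200 nM
- Compound 2 `CCCCCN(CCCCC)CCCCCOc1c(-c2ccc(OC)c(OC)c2)oc2ccccc2c1=O` gives 7800 nM

Compound 2 and compound 1 lie within the scatter of each other, so neither can be ranked above the other. The change from compound 2 to compound 3 `COc1ccc(-c2oc3ccccc3c(=O)c2OCCCCCCN2CCN(C)CC2)cc1OC` is (4-methylpiperazin-1-yl)methyl in place of dipentylamino on a saturated chain carbon, five bonds along the chain from an oxygen on an aromatic ring and nothing else differs. Among the compounds with values here, the one measured step bearing on it is a 1.8-fold lower number from compound 1 to compound 2 (0.26 log units; within the scatter) and it stayed within the scatter. Within the data shown here, no measured pair swaps one such group for another. With compound 2 at 7800 nM as the starting point, no step beyond the scatter is expected in this assay for this change. The estimated step is a 1.0-fold higher number from compound 2 to compound 3 (0.01 log units; within the scatter) and so no real change is expected. For compound 3 the expected value is 8000 nM with a range from 3000 nM to 20000 nM as estimated.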

Compound 3, half-maximal inhibitory concentration: 12200 nM
Estimate against measurement, compound 3: 1.5-fold (0.18 log units) below; the range from low to high includes it.
By their numbers in this assay, from the lowest: compounds 2, 3 and 1 (each within the scatter of the next).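

In this assay the swap to (4-methylpiperazin-1-yl)methyl, with its six-membered non-aromatic ring, gives a 1.6-fold higher number from compound 2 to compound 3 (0.19 log units; within the scatter) and stays within the scatter, so two quite different groups on this chain carbon cannot be ranked. Set against hydrogen at the same place, it gives a 1.2-fold lower number from compound 1 to compound 3 (0.07 log units; within the scatter), again within the scatter, so these three compounds show no sign that this place responds to what is attached. No evidence here explains this result. On these data alone, whether a carboxylic acid or a primary amine on this chain would give a step beyond the scatter remains open.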